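This account rests on a few compounds, and the source may have more. Where it says the series, first, only, none or still open, it means among the compounds named here.

The series shares one core, seen in compound 1 `Fc1ccccc1Cn1cc(CSC(=S)N2CCNCC2)nn1`, in which the group on the saturated chain carbon bound to an aromatic nitrogen is varied. In a functional assay on MCF7 cells (Homo sapiens) for inhibition, read by MTT assay, with a stated time of 72 h (a higher number here means a weaker inhibitor, a lower number a stronger inhibitor), compound 1 gives 33200 nM. Compound 2 `COc1ccc(Cn2cc(CSC(=S)N3CCNCC3)nn2)cc1` carries a methoxyphenyl group there, and in this assay compound 2 gives "not determined" (no result reported). Within the data shown here, compound 3 `S=C(SCc1cn(Cc2ccc(Cl)c(Cl)c2)nn1)N1CCNCC1` carries the 3,4-dichlorophenyl group, and in this assay compound 3 gives "not determined" (no result reported), so compound 3 stands without a number in this set and the only number on hand is that of compound 1.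

Compound 4 `S=C(SCc1cn(Cc2ccccc2Cl)nn1)N1CCNCC1` differs from compound 3 in one place: 2-chlorophenyl in place of 3,4-dichlorophenyl on a saturated chain carbon bound to an aromatic nitrogen. Among the measured compounds shown here, no step between measured compounds has been recorded, so nothing sets a size or direction for this change; the one number available, from compound 1, puts a related member of the series at weak inhibition, and no departure from that beyond the scatter is assumed. In this assay compound 4 is expected to give about 30000 nM, within a range of 8000 nM to 100000 nM.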

Compound 4, half-maximal inhibitory concentration: 38900 nM
The estimate for compound 4 lay 1.3-fold (0.11 log units) below the measured number; measured number inside the range.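

In this assay, among these compounds, the step of a 1.2-fold higher number from compound 1 to compound 4 (0.07 log units; within the scatter) gives the first comparison of two numbers, and swapping fluoro for chloro on an aromatic carbon leaves compound 4 in the same range as compound 1. Compounds 2 and 3 have no number, so steps involving them cannot be read, including the change from 3,4-dichlorophenyl to 2-chlorophenyl between compound 3 and compound 4. Nothing on hand accounts for this result.

Among the compounds shown here, only two halogen-bearing members can be compared so far, so it remains open whether any other group on the saturated chain carbon bound to an aromatic nitrogen shifts the number beyond the scatter. An amine or a carboxylic acid on the aromatic ring, or a longer chain at this place, would test that.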